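A few compounds are considered here, and "the series" means these few. Any claim that something is new, unique, unknown or untested is made for them only; others in the source may bear on it.

Within the data shown here, compound 1 `CCOc1ccc(C(=O)/C=C/c2ccc(F)cc2)cc1` is the only compound with a plain number in an assay on isolated protein for inhibition of Amine oxidase [flavin-containing] B (Homo sapiens) (on this read-out lower numbers stand for stronger inhibition and higher numbers for weaker inhibition), where compound 1 gives 53 nM. Compound 2 `COc1cccc(/C=C/C(=O)c2ccc(O/N=C(\C)c3cccs3)cc2)c1` stands only at a limit of the assay, < 300 nM, and so adds nothing beyond (the limit of < 300 nM in this assay, at which 1 of the 2 values shown sits). Compound 3 `CCOc1ccc(C(=O)/C=C/c2ccc(CC)cc2)cc1` differs from compound 1 by ethyl in place of fluoro on an aromatic carbon. No measured pair covers such an exchange and no shown value points either way, so a shift no larger than the usual scatter is expected, a 1.1-fold higher number from compound 1 to compound 3 (0.05 log units; within the scatter). Compound 3 is therefore expected near 60 nM, within 15 nM to 250 nM.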

Compound 3, half-maximal inhibitory concentration: 210 nM
Beside the measured number, compound 3's estimate is 3.5-fold (0.54 log units) below it, and the stated range covers the measured number.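

In this assay, ethyl in place of fluoro on an aromatic carbon, para to a large group, brings a 4.0-fold higher number from compound 1 to compound 3 (0.60 log units; beyond the scatter). This position therefore responds to the group it carries, and of the two groups, fluoro goes with the lower number. Nothing among the results shown accounts for this step. As far as these compounds go, how a methyl, a methoxy or an amine at this position would read remains open. With a single pair, the compounds shown give no trend across groups at this position.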